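Notes on the step from compound 3 to compound 4

The compounds below may be only part of what the source reports. "The series", "measured", "known", "first", "only" and "open" are said of these compounds alone.

Measured in an ADME assay on HeLa cells (Homo sapiens) for cytotoxicity, read by MTT assay; a lower number here means a stronger inhibitor, a higher number a weaker inhibitor:
- compound 1 `COc1ccc(C[C@H]2COC(=O)[C@@H]2Cc2ccc(OCc3cn(-c4ccc(Br)cc4)nn3)c(OC)c2)cc1OC`: 128000 nM
- compound 2 `COc1ccc(C[C@H]2COC(=O)[C@@H]2Cc2ccc(OCC(=O)N3CCCC3)c(OC)c2)cc1OC`: >= 600000 nM (a limit of the assay)
- compound 3 `COc1ccc(C[C@H]2COC(=O)[C@@H]2Cc2ccc(OCc3cn(-c4cccc(Cl)c4)nn3)c(OC)c2)cc1OC`: 493000 nM

Compound 3 holds the higher of the two actual numbers, as a 3.9-fold higher number from compound 1 to compound 3 (0.59 log units; beyond the scatter) shows. Compound 4 `COc1ccc(C[C@H]2COC(=O)[C@@H]2Cc2ccc(OCC(=O)N3CCOCC3)c(OC)c2)cc1OC` differs from it by (morpholin-4-yl)carbonyl in place of 1-(3-chlorophenyl)-1H-1,2,3-triazol-4-yl on a saturated chain carbon bound to an oxygen on an aromatic ring. The closest measured step is an at least 1.2-fold lower number from compound 2 to compound 3 (0.08 log units; that floor lies within the scatter), which has the same triazole and a related carbonyl group. Less direct is an at least 4.6-fold higher number from compound 1 to compound 2 (0.67 log units; beyond the scatter), where the aryl group on the triazole is 4-bromophenyl. No step beyond the scatter is expected in this assay, and a report of only a limit is likely. The estimated step is a 1.2-fold higher number from compound 3 to compound 4 (0.09 log units; within the scatter). For compound 4 the estimated value is 600000 nM, with an expected range of 300000 nM to 1000000 nM.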

Compound 4, half-maximal inhibitory concentration: >= 600000 nM
Compound 4 ended at the assay's limit; the forecaster's own chance of this, stated with the estimate: 65%; the middle value lies on the limit itself.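

In this assay, compound 4 gives a limit rather than a number, so a second (cyclic amine)carbonyl group on this saturated chain carbon also ends at the assay's ceiling: the limit of >= 600000 nM in this assay, at which 2 of the 4 values shown sit. Against the triazole compounds the change reads unevenly: an at least 4.6-fold higher number from compound 1 to compound 4 (0.67 log units; beyond the scatter), whereas an at least 1.2-fold higher number from compound 3 to compound 4 (0.08 log units; that floor lies within the scatter), so only the 4-bromophenyl triazole of compound 1 stands clearly apart. The step between compound 2 and compound 4 cannot be read, as both are limits.

Going by these compounds, whether a carboxylic acid or a diethylamino carbonyl group at this place would give a number below the limit remains open.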